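This account rests on a few compounds, and the source may have more. Where it says the series, first, only, none or still open, it means among the compounds named here.

In a functional assay on MOLT-4 cells (Homo sapiens) for cytotoxicity (a lower number here means a stronger inhibitor, a higher number a weaker inhibitor), compound 1 `O=S(=O)(N/C(=N\O)Nc1ccc(Cl)cc1)c1cc(C(F)(F)F)cc(C(F)(F)F)c1` gives 44 ug/mL and compound 2 `O=[N+]([O-])c1ccc(Oc2c(Cl)cc(S(=O)(=O)N/C(=N\O)Nc3ccc(Cl)cc3)cc2Cl)cc1` gives 55 ug/mL. These two values lie within the usual scatter of each other, so neither compound can be ranked above the other. Compound 3 `O=[N+]([O-])c1ccc(Oc2c(Cl)cc(S(=O)(=O)N/C(=N\O)Nc3ccc(Cl)cc3)cc2Cl)c(Cl)c1` keeps the frame of compound 2 but has chloro in place of hydrogen on an aromatic carbon, ortho to a large group and meta to a nitro group, so that 4-nitrophenyl becomes 2-chloro-4-nitrophenyl: chloro in place of hydrogen on an aromatic carbon. Among the measured compounds shown here, no measured pair shows what this single change does in this assay. For the measured compounds named here, the only guide is how close the two measured values are, so a small move is expected, with no shift beyond the scatter. The expected step is a 1.1-fold lower number from compound 2 to compound 3 (0.06 log units; within the scatter). For compound 3 the estimated value is 48 ug/mL, with an expected range of 22 ug/mL to 95 ug/mL.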

Compound 3, half-maximal inhibitory concentration: 56 ug/mL
The estimate for compound 3 lay 1.2-fold (0.07 log units) below the measured number; the measured number falls inside the stated range.
By their numbers in this assay, from the lowest: compounds 1, 2 and 3 (each within the scatter of the next).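

In this assay, chloro in place of hydrogen on the aromatic carbon ortho to a large group and meta to a nitro group gives a 1.0-fold higher number from compound 2 to compound 3 (0.01 log units; within the scatter). Among the compounds shown here, this is the first comparison of compounds that differ in one place, and it shows that 4-nitrophenoxy and 2-chloro-4-nitrophenoxy cannot be told apart in this read-out, since the added chlorine atom leaves the number within the scatter. Nothing available here accounts for this result.

Open, going by these compounds, is whether this position would tolerate other groups in the same way, such as an amine, a methoxy group or a carboxylic acid on the same aromatic carbon. Also open, on these data alone, is how the number would respond if the nitro group itself gave way to a nitrile or an amine.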